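The source may hold more compounds than are shown below. What is called first, only, known or untested is meant among the compounds shown, and "the series" means these compounds.

Working notes on the series. In an ADME assay on S9 fraction from liver (Mus musculus, strain ICR/CD-1) for metabolic stability, read by LC-MS, using NADPH, with a stated time of 5 min, tested at 2 uM (a lower number here means that the compound disappears faster, a higher number that the compound lasts longer), compound 1 (`Cc1c(C)c(S(=O)(=O)N2CCC(N3CCC(C)CC3)CC2)c(C)c2c1OC(C)(C)C2`) gives 1.12 h, compound 2 (`CC1CCN(C2CCN(S(=O)(=O)c3ccccc3Br)CC2)CC1`) gives 0.1 h and compound 3 (`COc1ccccc1-c1cccc(S(=O)(=O)N2CCC(N3CCC(C)CC3)CC2)c1`) gives 0.25 h. Compound 3 therefore stands second of the three, above compound 2 and below compound 1, with both gaps beyond the scatter.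

The next compound to be read is compound 4 (`CC1CCN(C2CCN(S(=O)(=O)c3cccc(-c4ccccc4C(F)(F)F)c3)CC2)CC1`). It differs from compound 3 in one place: trifluoromethyl in place of methoxy on an aromatic carbon. This puts trifluoromethyl in place of methoxy on an aromatic carbon, ortho to a large group, turning 2-methoxyphenyl into 2-(trifluoromethyl)phenyl. Going by the values given here, no measured pair shows this change, so the expectation in this assay starts from compound 3 at 0.25 h and has no direct precedent. A small upward move that may stay within the scatter is expected, and the estimated step is a 1.4-fold higher number from compound 3 to compound 4 (0.15 log units; within the scatter). For compound 4 the expected half-life is 0.35 h, with an estimated range of 0.15 h to 0.8 h.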

Compound 4, half-life: 0.617 h
Estimate against measurement, compound 4: 1.8-fold (0.25 log units) below; the range from low to high includes it.
By their numbers in this assay, from the lowest: compound 2; then compound 3; then compounds 4 and 1 (each within the scatter of the next).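

In this assay, going by these compounds alone, the change from 2-methoxyphenyl to 2-(trifluoromethyl)phenyl gives a 2.5-fold higher number from compound 3 to compound 4 (0.39 log units; beyond the scatter), the only step so far between compounds that differ in one place. It shows that the group on this aromatic carbon, ortho to a large group, can alone move the half-life beyond the scatter while the rest of compound 3 stays the same. Nothing at hand bears on why the number rises with this change.

As far as these compounds go, with a single pair, it remains open whether the step is tied to the loss of methoxy or to the arrival of trifluoromethyl; a methyl, a chlorine atom or a nitrile at the same place would separate the two. From the compounds shown here alone, it also remains open whether the same change gives a similar step elsewhere.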